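The source may report more compounds than this note shows. Statements on the series, on what has been measured and on what is new or still open speak of the compounds shown alone.

Series notes. All three measured compounds share the core seen in compound 1, `Cc1ncc([N+](=O)[O-])n1CCSc1nnc(-c2ccc([N+](=O)[O-])cc2)o1`, and differ only in the group attached to the ring at the far end. In a functional assay on SGC-7901 cells (Homo sapiens) for cytotoxicity, read by MTT assay, with a stated time of 48 h (a higher number here means a weaker inhibitor, a lower number a stronger inhibitor), compound 1 gives 12200 nM. Compound 2, `Cc1ncc([N+](=O)[O-])n1CCSc1nnc(-c2ccc(F)cc2)o1`, gives 5300 nM, and compound 3, `Cc1ncc([N+](=O)[O-])n1CCSc1nnc(-c2ccc(N(C)C)cc2)o1`, gives 32800 nM. Compound 2 therefore holds the lowest number of the three: the step of a 2.3-fold lower number from compound 1 to compound 2 (0.36 log units; beyond the scatter) and the step of a 6.2-fold higher number from compound 2 to compound 3 (0.79 log units; beyond the scatter) both lie beyond the scatter, as does a 2.7-fold higher number from compound 1 to compound 3 (0.43 log units; beyond the scatter).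

Compound 4, `Cc1ncc([N+](=O)[O-])n1CCSc1nnc(-c2cccnc2)o1`, is not yet measured. Against compound 2 the change is pyridin-3-yl in place of 4-fluorophenyl on an aromatic carbon. Among the compounds with values here, none of the measured steps bears on this change directly: each of them swaps one group on an aromatic carbon of a six-membered aromatic ring of carbon only, whereas here the whole 4-fluorophenyl is exchanged for pyridin-3-yl. Within the data shown here, the measured steps show only that swaps at this end move the number by modest amounts, in either direction, so a step of similar size is the most that can be expected, with no clear direction.

Compound 4 is expected to come in near 8000 nM, within 3000 nM to 25000 nM. The expected step of a 1.5-fold higher number from compound 2 to compound 4 (0.18 log units; within the scatter) stays within the scatter.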

Compound 4, half-maximal inhibitory concentration: 31600 nM
Compound 4: the middle estimate sits 4.0-fold (0.60 log units) below what was measured, and the stated range ends below it.
By their numbers in this assay, from the lowest: compound 2; then compound 1; then compounds 4 and 3 (each within the scatter of the next).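

In this assay, within the data shown here, replacing the whole ring at this position is not a neutral exchange: a 6.0-fold higher number from compound 2 to compound 4 (0.78 log units; beyond the scatter) is a step beyond the scatter, and it is the first measured change of the ring itself rather than of a group on a carbon-only ring. Compound 4 at 31600 nM and compound 3 at 32800 nM lie within the scatter of each other, so a single ring nitrogen in pyridin-3-yl, with no further group on that ring, leaves the number in the same range as dimethylamino on the phenyl ring, and compound 2 remains the strongest of the four in this assay. No measurement at hand accounts for the step.

The change removes the fluorine and brings in a ring nitrogen with a hydrogen-bond acceptor at once, and the compounds shown do not separate these two parts; an unsubstituted phenyl or a fluoro-substituted pyridin-3-yl would do so. As far as these compounds go, the pyridin-2-yl and pyridin-4-yl isomers also remain open, as does a saturated ring such as piperidine at this position.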